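Nitro for methoxy on the aryl ring of compound 1

This account rests on a few compounds, and the source may have more. Where it says the series, first, only, none or still open, it means among the compounds named here.

Compound 1 `COC(=O)C1=C(C)N=C(C)/C(=C(\O)OC)C1c1cccc(OC)c1` holds the highest number of the two measured: in a functional assay (muscle tissue) with Cavia porcellus as the target (on this read-out lower numbers stand for an effect already at smaller amounts and higher numbers for an effect only at larger amounts of compound), compound 1 gives 191 nM, while compound 2 `C=Cc1ccccc1C1C(C(=O)OC)=C(C)N=C(C)/C1=C(\O)OC` gives 4.47 nM. Going by the values given here, the only measured step, a 43-fold lower number from compound 1 to compound 2 (1.63 log units; beyond the scatter), shows that a change on the aryl ring can move this read-out far. Compound 3 `COC(=O)C1=C(C)N=C(C)/C(=C(\O)OC)C1c1cccc([N+](=O)[O-])c1` differs from compound 1 by nitro in place of methoxy on an aromatic carbon. Among the compounds with values here, no measured step matches this exact change, so the direction is uncertain; a step of some size is expected, and compound 3 is estimated at 60 nM (range 8 nM to 400 nM), a step of a 3.2-fold lower number from compound 1 to compound 3 (0.50 log units; beyond the scatter) expected.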

Compound 3, half-maximal effective concentration: 3.98 nM
Compound 3: the middle estimate sits 15-fold (1.18 log units) above what was measured; measured number below the stated range.
By their numbers in this assay, from the lowest: compounds 3 and 2 (each within the scatter of the next); then compound 1.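

Nitro in place of methoxy on this aromatic carbon gives a 48-fold lower number from compound 1 to compound 3 (1.68 log units; beyond the scatter) in this assay. The position that carries methoxy in compound 1 is thus itself sensitive: a single group exchanged there moves the number far, with the aryl ring otherwise unchanged, whereas the earlier step to compound 2 replaced the whole 3-methoxyphenyl group. Nothing available accounts for the size of this step.

Going by these compounds, it remains open how an amine, a nitrile or a carboxylic acid would read at this same place. On these data alone, it is also open whether a hydrogen there would stand nearer to compound 1 or to compound 3.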